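From dipropylamino to anilino on a shared core

A few compounds are considered here, and "the series" means these few. Any claim that something is new, unique, unknown or untested is made for them only; others in the source may bear on it.

Compound 1 `O=C1C=C(NC2CCCC2)C(=O)c2c1nc1n2[C@H]2OC[C@@H](O)[C@H]2OC1`, compound 2 `COc1ccc(NC2=CC(=O)c3nc4n(c3C2=O)[C@H]2OC[C@@H](O)[C@H]2OC4)cc1` and compound 3 `CCCN(CCC)C1=CC(=O)c2nc3n(c2C1=O)[C@H]1OC[C@@H](O)[C@H]1OC3` share one core. In a functional assay on MGC-803 cells (Homo sapiens) for inhibition, read by sulforhodamine B assay (on this read-out lower numbers stand for stronger inhibition and higher numbers for weaker inhibition), compound 2 gives 1680 nM. Compound 1 gives > 8000 nM, which is a limit of the assay and not a number. Compound 3 gives > 16000 nM, which is also a limit, so compound 3 has no exact value to start from.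

Compound 4 `O=C1C=C(Nc2ccccc2)C(=O)c2c1nc1n2[C@H]2OC[C@@H](O)[C@H]2OC1` carries anilino in place of dipropylamino on a double-bonded ring carbon. Compound 2 also holds an aromatic ring on its amine nitrogen, and two measured steps bear on that ring. Putting 4-methoxyphenyl in place of cyclopentyl gave an at least 4.7-fold lower number from compound 1 to compound 2 (0.67 log units; beyond the scatter). Putting dipropylamino in place of (4-methoxyphenyl)amino gave an at least 9.5-fold higher number from compound 2 to compound 3 (0.97 log units; beyond the scatter). Going by the values given here, both steps lie beyond the scatter, but no measured step isolates the methoxy group, so the size remains uncertain.

A clear drop in the number is therefore expected, and the estimated step is an at least 5.3-fold lower number from compound 3 to compound 4 (0.72 log units; beyond the scatter). For compound 4 the expected value is 3000 nM, with an estimated range of 1000 nM to 9000 nM.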

Compound 4, half-maximal inhibitory concentration: 1730 nM
Beside the measured number, compound 4's estimate is 1.7-fold (0.24 log units) above it; low and high end bracket the measured number.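

The swap of dipropylamino for anilino on the double-bonded ring carbon gives an at least 9.2-fold lower number from compound 3 to compound 4 (0.96 log units; beyond the scatter) even though the two groups have the same number of heavy atoms, so what separates them is the aromatic ring and the hydrogen-bond donor that anilino brings. Hydrogen in place of methoxy gives a 1.0-fold higher number from compound 2 to compound 4 (0.01 log units; within the scatter) and so shows that the plain phenyl ring does as well as 4-methoxyphenyl here. Phenyl in place of cyclopentyl gives an at least 4.6-fold lower number from compound 1 to compound 4 (0.66 log units; beyond the scatter) and thus ties the gain to the aromatic ring without any help from methoxy.

From the compounds shown here alone, the steps from compound 1 and compound 3 both start from limits of the assay, so their true sizes stay open. Also open, going by these compounds, is whether the donor or the ring matters more, and whether a chlorine or a carboxylic acid on the phenyl ring would shift the number.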